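Benzylation of compound 2 in the cell assay

The source may report more compounds than this note shows. Statements on the series, on what has been measured and on what is new or still open speak of the compounds shown alone.

Values in an ADME assay on CHO cells (Cricetulus griseus) for inhibition, read by MTT assay; a lower number here means a stronger inhibitor, a higher number a weaker inhibitor:
- compound 1 `CC(C)(C)NCc1cc(Cl)cc(Nc2nc3ccccc3n2Cc2ccc(C(F)(F)F)cc2)c1O`: 36300 nM
- compound 2 `CCN(CC)Cc1ccc(Nc2nc3ccccc3[nH]2)cc1O`: > 50000 nM (a limit)
- compound 3 `CCN(CC)Cc1ccc(C)c(Nc2nc3ccccc3[nH]2)c1O`: > 50000 nM (a limit)

Compound 2 gives only a limit, > 50000 nM, and not a number. Compound 3 also gives only a limit, > 50000 nM. Taken together, the series so far shows (the limit of > 50000 nM in this assay, at which 2 of the 3 values shown sit). Among the compounds with values here, compound 1 is the only one with a number, 36300 nM, and it carries 4-(trifluoromethyl)benzyl on an aromatic nitrogen, though it differs from compound 2 elsewhere as well.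

The next compound is compound 4 `CCN(CC)Cc1ccc(Nc2nc3ccccc3n2Cc2ccc(C(F)(F)F)cc2)cc1O`, which stays close to compound 2. The change is 4-(trifluoromethyl)benzyl in place of hydrogen on an aromatic nitrogen. Within the data shown here, no measured pair isolates this change in this assay, so the only guide is compound 1 at 36300 nM. A modest shift toward stronger inhibition is expected, about the size of the usual scatter or slightly more, and another limit reading remains possible. The estimated step of an at least 1.7-fold lower number from compound 2 to compound 4 (0.25 log units; that floor lies within the scatter) is correspondingly small. For compound 4 the expected value is 28000 nM, with an estimated range of 10000 nM to 50000 nM.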

Compound 4, half-maximal inhibitory concentration: 41500 nM
Compound 4: middle estimate off by 1.5-fold (0.17 log units), on the low side; the range from low to high includes it.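

In this assay, 4-(trifluoromethyl)benzyl in place of hydrogen on the aromatic nitrogen can now be read as a single change, and it gives an at least 1.2-fold lower number from compound 2 to compound 4 (0.08 log units; that floor lies within the scatter). Within the data shown here, with this group on the nitrogen, compound 4 gives a measured number, 41500 nM, so this pair brings the first reading on the shared core of compound 2 that is not a limit of the assay. The step remains only a floor and does not give a size, because one end of the pair is a limit: the limit of > 50000 nM in this assay, at which 2 of the 4 values shown sit.

Going by these compounds, how far the unknown value of compound 2 lies from its limit stays open, so the true step may lie within the scatter or well beyond it. Also open is whether the effect belongs to the 4-(trifluoromethyl)benzyl group as a whole, since the compounds shown give no reading for a plain benzyl, a methyl or a benzyl carrying a carboxylic acid on this nitrogen.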